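A few compounds are considered here, and "the series" means these few. Any claim that something is new, unique, unknown or untested is made for them only; others in the source may bear on it.

The series shares one core and differs only in the group carried on the amide-type nitrogen of the side chain. Compound 1 is `COCOc1cc(/C=C/C(=O)OCC(=O)Nc2ccc(Cl)cc2)ccc1OCc1ccccc1`. Compound 2 is `COCOc1cc(/C=C/C(=O)OCC(=O)NN2CCOCC2)ccc1OCc1ccccc1`. Compound 3 is `COCOc1cc(/C=C/C(=O)OCC(=O)Nc2nccs2)ccc1OCc1ccccc1`. Compound 4, not yet measured, is `COCOc1cc(/C=C/C(=O)OCC(=O)NCc2ccco2)ccc1OCc1ccccc1`.

In a functional assay on ECa-109 cells (Homo sapiens) for cytotoxicity, read by MTT assay, with a stated time of 72 h (on this read-out higher numbers stand for weaker inhibition and lower numbers for stronger inhibition), compound 1 returns only a limit, > 200000 nM. In this assay compound 2 gives 143000 nM. In this assay compound 3 likewise returns only a limit, > 200000 nM. Given (the limit of > 200000 nM in this assay, at which 2 of the 3 values shown sit), compound 3 stands at the top of the range shown, without a number of its own. The measured steps read an at least 1.3-fold lower number from compound 1 to compound 2 (0.14 log units; that floor lies within the scatter), a step that the two limits leave unreadable from compound 1 to compound 3 and an at least 1.3-fold higher number from compound 2 to compound 3 (0.14 log units; that floor lies within the scatter); none of them rises beyond the scatter.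

The move to compound 4 is (furan-2-yl)methyl in place of 1,3-thiazol-2-yl on an amide-type nitrogen. Going by the values given here, no measured step covers this change; the three measured steps, all small or unreadable, show only that changing the group on the amide-type nitrogen has so far left every value near or at the limit. The step expected in this assay is an at least 1.1-fold lower number from compound 3 to compound 4 (0.04 log units; that floor lies within the scatter), nothing beyond the scatter, with a fair chance that only a limit returns again. Compound 4 is estimated at 180000 nM, within 90000 nM to 350000 nM.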

Compound 4, half-maximal inhibitory concentration: > 200000 nM
Compound 4 gave a limit, no number; the forecaster's own chance of this, stated with the estimate: 55%; middle value at least 1.1-fold (0.04 log units) away from the limit.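

In this assay compound 4 returns only a limit, > 200000 nM. With (furan-2-yl)methyl, the aromatic ring now sits on a methyl rather than directly on the amide-type nitrogen, and this form of attachment has still not given a value clear of the limit that compounds 1 and 3 also reach: the limit of > 200000 nM in this assay, at which 3 of the 4 values shown sit.

Going by these compounds alone, the one readable comparison is an at least 1.3-fold higher number from compound 2 to compound 4 (0.14 log units; that floor lies within the scatter), so no group on this nitrogen has yet separated from morpholin-4-yl beyond the scatter. The steps from compound 1 and from compound 3 to compound 4 cannot be read, as both ends of each are limits.

Open, as far as these compounds go, is whether any group on this nitrogen, such as a 2-(dimethylamino)ethyl group or a carboxymethyl group, would give a value well clear of the limit. Also open, from the compounds shown here alone, is whether a change away from this nitrogen, such as a free hydroxyl in place of the methoxymethyl ether on the shared core, would move the values in a way that no change of group on the amide-type nitrogen has done so far.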